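Removing a nitro group in the diaryl ether series

The compounds below may be only part of what the source reports. "The series", "measured", "known", "first", "only" and "open" are said of these compounds alone.

Compound 1 `Cc1ccc(Nc2cc(Oc3c(C)cc(Br)cc3C)c([N+](=O)[O-])cc2[N+](=O)[O-])cc1` is the reference of the set; in an ADME assay on H9 cells (Homo sapiens) for cytotoxicity, read by XTT assay, with a stated time of 6 days (a higher number here means that more compound is tolerated, a lower number that less compound is tolerated), compound 1 gives 53000 nM. Compound 2 `Cc1cc(Br)cc(C)c1Oc1cc(Nc2ccc([N+](=O)[O-])cc2)c([N+](=O)[O-])cc1[N+](=O)[O-]` carries nitro in place of methyl on an aromatic carbon, and in this assay compound 2 gives only a limit, > 49700 nM. Compound 3 `Cc1cc(Br)cc(C)c1Oc1cc(Nc2ccc(C#N)cc2)c([N+](=O)[O-])cc1[N+](=O)[O-]` carries cyano in place of methyl on an aromatic carbon; in this assay compound 3 also gives only a limit, > 51700 nM. The steps a step that the limit leaves unreadable from compound 1 to compound 2, a step that the limit leaves unreadable from compound 1 to compound 3 and a step that the two limits leave unreadable from compound 2 to compound 3 cannot be sized because the limit of > 49700 nM in this assay, at which 1 of the 3 values shown sits, and the limit of > 51700 nM in this assay, at which 1 of the 3 values shown sits, cap them. Compound 3 therefore stands at a limit, with one further value also at a limit. Compound 4 `Cc1cc(Br)cc(C)c1Oc1ccc([N+](=O)[O-])c(Nc2ccc(C#N)cc2)c1` differs from compound 3 by hydrogen in place of nitro on an aromatic carbon. Among the measured compounds shown here, no measured step bears on this change, so no step beyond the scatter is expected. Compound 4 is estimated at 45000 nM, range 20000 nM to 90000 nM, an expected step of an at least 1.1-fold lower number from compound 3 to compound 4 (0.06 log units; that floor lies within the scatter).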

Compound 4, half-maximal cytotoxic concentration: > 57000 nM
Compound 4 ended at the assay's limit (the forecaster's own chance of this, stated with the estimate: 50%); middle value at least 1.2-fold (0.10 log units) from the limit.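

Compound 3 and compound 4 both stand at limits in this assay; the step between them cannot be read. The compounds shown leave open whether hydrogen in place of nitro shifts the half-maximal cytotoxic concentration at all.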